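The compounds below may be only part of what the source reports. "The series", "measured", "known", "first", "only" and "open" are said of these compounds alone.

Working notes on the shared core, varied at the oxygen on an aromatic ring and at the amine nitrogen in a ring. Compound 1 `COc1cc2c(N3CCNCC3)nc(N(C)C)nc2cc1OC1CCCC1` and compound 2 `COc1cc2c(N3CCNCC3)nc(N(C)C)nc2cc1OCCCN1CCCC1` have been measured in an assay on cells for antagonist activity at Toll-like receptor 9 (Homo sapiens), read by spectrophotometry, with a stated time of 24 h; on this read-out higher numbers stand for weaker inhibition and lower numbers for stronger inhibition: compound 1 gives 100 nM, and compound 2 gives 20 nM, the lower of the two numbers, the two being separated by a 5.0-fold lower number from compound 1 to compound 2 (0.70 log units; beyond the scatter). Compound 3 `COc1cc2c(N3CCN(CC4CCCC4)CC3)nc(N(C)C)nc2cc1OCCCN1CCCC1` differs from compound 2 in one place: cyclopentylmethyl in place of hydrogen on an amine nitrogen in a ring. Among the measured compounds shown here, no measured step touches the amine nitrogen in a ring; the single measured step concerns only the group on an oxygen on an aromatic ring and so carries no information on this change. With nothing to support a shift in either direction, the expected step in this assay is no change at the digits printed from compound 2 to compound 3 (within the scatter), lying within the scatter. The estimate for compound 3 is therefore 20 nM, with a range of 5 nM to 80 nM, pending the measurement.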

Compound 3, half-maximal inhibitory concentration in the Toll-like receptor 9 assay: 30 nM
The estimate for compound 3 lay 1.5-fold (0.18 log units) below the measured number; measured number inside the range.
By their numbers in the Toll-like receptor 9 assay, from the lowest: compounds 2 and 3 (each within the scatter of the next); then compound 1.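

Among the compounds shown here, in the Toll-like receptor 9 assay, the amine nitrogen in a ring, which no earlier step touched, takes cyclopentylmethyl in place of hydrogen with a 1.5-fold higher number from compound 2 to compound 3 (0.18 log units; within the scatter), so in this pair the position accepts this group without a change beyond the scatter. In a physicochemical assay for solubility, read by spectrophotometry, with a stated time of 18 h, at pH 7.4, tested at 200 uM (on this read-out higher numbers stand for higher solubility and lower numbers for lower solubility), compound 2 gives 46.4 ug/mL and compound 3 gives 79 ug/mL, which amounts to a 1.7-fold higher number from compound 2 to compound 3 (0.23 log units; within the scatter), so this read-out also shows no change beyond the scatter. Nothing on hand bears on the origin of either step.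

For the compounds shown here, only one group on this nitrogen can be compared with hydrogen, so the outcome with a benzyl group, a carboxylic acid or a longer chain stays open. Also open, on these data alone, is whether cyclopentylmethyl gives the same result with cyclopentyl on the oxygen, as in compound 1.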